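Notes on the step from compound 3 to compound 4

The source may report more compounds than this note shows. Statements on the series, on what has been measured and on what is new or still open speak of the compounds shown alone.

Measured so far in a physicochemical assay for lipophilicity, at pH 7.4; on this read-out lower numbers stand for lower lipophilicity and higher numbers for higher lipophilicity:
- compound 1 `CCNC(=O)c1cc(C(=O)NC)c(=O)n(Cc2ccccc2)c1` gives 3
- compound 2 `CNC(=O)c1cc(C(=O)NC2CC2)c(C)n(Cc2ccccc2)c1=O` gives 2.9
- compound 3 `CNC(=O)c1cc(C(=O)NC2CC2)cn(Cc2nccc3[nH]ccc23)c1=O` gives 1.7

Compound 3 stands lowest of the three, and both other compounds lie higher by more than the scatter. Compound 1 and compound 2 lie within the scatter of each other.

Compound 4 `CNC(=O)c1cc(C(=O)NC2CC2)cn(Cc2ccc3nc[nH]c3c2)c1=O` is still unmeasured. Its difference from compound 3 is a group of 9 heavy atoms (7 carbon, 2 nitrogen; one five-membered aromatic ring with 2 hetero atoms, one six-membered aromatic ring of carbon only) in place of a group of 9 heavy atoms (7 carbon, 2 nitrogen; one five-membered aromatic ring with 1 hetero atom, one six-membered aromatic ring with 1 hetero atom), on a saturated chain carbon bound to an aromatic nitrogen (the two have the same atoms, joined differently, and the entering group is 1H-benzimidazol-6-yl).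

Among the compounds with values here, no pair of measured compounds differs in one place only, so the series offers no measured step as a guide in this assay. The gaps from compound 3 to compound 1 and compound 2 involve other differences as well and are not used here. The expectation therefore starts from compound 3 at 1.7 as the measured structure with the same atoms as compound 4. No step beyond the scatter is expected, with at most a slight rise. The estimated step is a number 0.20 log units higher from compound 3 to compound 4 (within the scatter) and it stays within the scatter. The expected value for compound 4 is 1.9 (estimated range 1.4 to 2.4).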

Compound 4, distribution coefficient: 1.2
Estimate against measurement, compound 4: 0.70 log units above, outside the stated range (below it).
By their numbers in this assay, from the lowest: compound 4; then compound 3; then compounds 2 and 1 (each within the scatter of the next).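

In this assay, the position on a saturated chain carbon bound to an aromatic nitrogen responds to how the atoms of the group are joined, not only to which atoms it holds: with 1H-benzimidazol-6-yl as the entering group, the read-out moves by a number 0.50 log units lower from compound 3 to compound 4 (beyond the scatter). The leaving and entering groups have the same heavy atoms, the same counts of hydrogen-bond donors and acceptors, and no net charge, so these counts alone do not settle the read-out at this position. No measurement at hand accounts for the step.

This is a single step on a single pair, so it cannot yet be said whether it would carry over to the other amide groups or the methyl-bearing core seen in compound 1 and compound 2. The compounds shown also leave open how 1H-indazol-6-yl, which has the same heavy atoms, would read at this place, and what an amine or a carboxylic acid on the 1H-benzimidazol-6-yl group would do to the number.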